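The source may report more compounds than this note shows. Statements on the series, on what has been measured and on what is new or still open speak of the compounds shown alone.

Compound 1, `C[C@H](Nc1nc(N)nc(N)c1C#N)c1cc2ccc(F)cn2c(=O)c1-c1ccccc1`, was examined in an ADME assay on microsomes from liver (Homo sapiens), read by LC-MS, using NADPH, with a stated time of 30 min, tested at 1 uM (a higher number here means that more of the compound is left, a lower number that less of the compound is left), and in that setting compound 1 gives 87%. Compound 2, `C[C@H](Nc1nc(N)ncc1C#N)c1cc2ccc(F)cn2c(=O)c1-c1ccccc1`, differs from compound 1 by hydrogen in place of amino on an aromatic carbon; in this assay compound 2 gives 90%. The step of a number 3 percentage points higher from compound 1 to compound 2 (within the scatter).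

Compound 3, `C[C@H](Nc1nc(N)nc(N)c1C#N)c1cc(=O)n2cc(F)ccc2c1-c1ccccc1`, is built from the same atoms as compound 1, joined differently; how the two cores differ is not broken down here. In this assay compound 3 gives "not determined" (no result reported), so no single number is available for it.

Compound 4, `C[C@H](Nc1ncnc(N)c1C#N)c1cc(=O)n2cc(F)ccc2c1-c1ccccc1`, differs from compound 3 by hydrogen in place of amino on an aromatic carbon. Among the compounds with values here, this is the same kind of change as the one from compound 1 to compound 2, but not the same: in compound 1 the leaving amino stands next to the ring nitrogen, ortho to a cyano group and opposite the ring nitrogen, whereas in compound 3 it stands between two ring nitrogen atoms and para to a cyano group.

Any expectation for compound 4 therefore rests on the measured pair alone, since compound 3 itself has no number. Because the step of a number 3 percentage points higher from compound 1 to compound 2 (within the scatter) stays within the scatter, the step from compound 3 to compound 4 is expected to be small as well. In this assay compound 4 is expected to give an estimated 85%, with a likely range from 70% to 97%.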

Compound 4, percent of the compound remaining: 90%
Estimate against measurement, compound 4: 5 percentage points below, and the stated range covers the measured number.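

In this assay, within the data shown here, compound 4 gives 90%, but compound 3 has no number to set against it, so no step from compound 3 to compound 4 can be read. The compounds shown leave open whether replacing 2,6-diamino-5-cyanopyrimidin-4-yl with 6-amino-5-cyanopyrimidin-4-yl on this core changes the percent remaining at all. Nothing shown here accounts for these values.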